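Swapping the ring-nitrogen substituent of compound 3 for an oxadiazole carbonyl

The source may report more compounds than this note shows. Statements on the series, on what has been measured and on what is new or still open speak of the compounds shown alone.

Compound 3 `Cc1nc(S(C)(=O)=O)ccc1Oc1ncnc(OC2CCN(C(=S)OC(C)C)CC2)c1F` stands lowest of the three compounds measured in a functional assay on isolated protein for inhibition of Glucose-dependent insulinotropic receptor (Rattus norvegicus), read by HTRF and cAMP accumulation; on this read-out higher numbers stand for larger maximal responses and lower numbers for smaller maximal responses: compound 3 gives 47%, compound 2 `Cc1nc(S(C)(=O)=O)ccc1Oc1ncnc(OC2CCN(C(=O)OC3COC3)CC2)c1F` gives 66%, and compound 1 `Cc1nc(S(C)(=O)=O)ccc1Oc1ncnc(OC2CCN(C(=O)OC(C)(C)CF)CC2)c1F` gives 95%. Compound 4 `Cc1nc(S(C)(=O)=O)ccc1Oc1ncnc(OC2CCN(C(=O)c3noc(C(C)C)n3)CC2)c1F` differs from compound 3 in one place: a group of 10 heavy atoms (6 carbon, 2 nitrogen, 2 oxygen; one five-membered aromatic ring with 3 hetero atoms) in place of a group of 6 heavy atoms (4 carbon, 1 oxygen, 1 sulfur; no ring), on an amine nitrogen in a ring. Within the data shown here, the steps that bear on this change both alter the group on the same amine nitrogen in a ring, and both were drops toward compound 3: a number 48 percentage points lower from compound 1 to compound 3 (beyond the scatter), and a number 19 percentage points lower from compound 2 to compound 3 (beyond the scatter). Since compounds 1 and 2, which carry a carbonyl on that nitrogen as compound 4 does, both sit well above compound 3, a rise beyond the scatter is expected for compound 4, with a number 28 percentage points higher from compound 3 to compound 4 (beyond the scatter). Compound 4 is therefore estimated at 75%, within 50% to 100%.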

Compound 4, largest response reached (reported as efficacy), in percent of the reference or control that the assay uses: 81%
Compound 4: the middle estimate sits 6 percentage points below what was measured; the range from low to high includes it.
By their numbers in this assay, from the lowest: compound 3; then compound 2; then compound 4; then compound 1.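

With a five-membered aromatic ring on the carbonyl, the amine nitrogen in the ring still gives a large maximal response in this assay: the change gives a number 34 percentage points higher from compound 3 to compound 4 (beyond the scatter). A carbonyl without the carbamate oxygen thus reaches beyond the oxetanyl carbamate, with a number 15 percentage points higher from compound 2 to compound 4 (beyond the scatter), yet falls short of the fluorinated carbamate, with a number 14 percentage points lower from compound 1 to compound 4 (beyond the scatter). Nothing available accounts for these steps. The compounds shown leave open how much the isopropyl on the oxadiazole contributes, and whether a cyclopropyl or a tert-butyl group there would give the same response.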